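The compounds below may be only part of what the source reports. "The series", "measured", "known", "first", "only" and "open" are said of these compounds alone.

Of the compounds shown here, three built on a shared core have been measured in an assay on HEK293 cells for displacement of a labelled ligand from Type-2 angiotensin II receptor (Homo sapiens), tested at 10 uM; on this read-out higher numbers stand for a stronger effect at the one concentration tested and lower numbers for a weaker effect. In this assay compound 1 `CC[C@H](C)[C@H](NC(=O)c1cccc(Cn2ccnc2)c1)C(=O)Nc1nccs1` gives 17%, compound 2 `CCCCNC(=O)[C@@H](NC(=O)c1cccc(Cn2ccnc2)c1)[C@@H](C)CC` gives 3%, and compound 3 `CC[C@H](C)[C@H](NC(=O)c1cccc(Cn2ccnc2)c1)C(=O)NNS(=O)(=O)c1ccc(C)cc1` gives 20%. Compound 3 carries the highest of the three numbers, but its separation from compound 1 is only a number 3 percentage points higher from compound 1 to compound 3 (within the scatter), so these two cannot be ordered; its separation from compound 2, a number 17 percentage points higher from compound 2 to compound 3 (beyond the scatter), is real.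

Compound 4 `CC[C@H](C)[C@H](NC(=O)c1cccc(Cn2ccnc2)c1)C(=O)NC#N` has not yet been measured. It differs from compound 3 by cyano in place of ((4-methylphenyl)sulfonyl)amino on an amide-type nitrogen. Going by the values given here, two measured steps concern the same amide-type nitrogen: a number 3 percentage points higher from compound 1 to compound 3 (within the scatter) and a number 17 percentage points higher from compound 2 to compound 3 (beyond the scatter), with a number 14 percentage points lower from compound 1 to compound 2 (beyond the scatter) linking the other pair. Replacements at this position have thus moved the read-out by between a few and roughly a score of percentage points, with the smallest group, butyl, giving the lowest number.

On that basis compound 4 is expected to come out somewhat lower than compound 3, by an estimated a number 10 percentage points lower from compound 3 to compound 4 (within the scatter). The estimate for compound 4 in this assay is 10%, with a likely range from 0% to 24%.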

Compound 4, a percentage reported as inhibition, at one concentration (the size of the read-out at that concentration, not a potency): 9%
Compound 4: middle estimate off by 1 percentage points, on the high side; low and high end bracket the measured number.
By their numbers in this assay, from the lowest: compounds 2, 4, 1 and 3 (each within the scatter of the next, the first and the last beyond it).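

In this assay, going by these compounds alone, cyano is the first replacement on this amide-type nitrogen to be separated from the ((4-methylphenyl)sulfonyl)amino group, with a number 11 percentage points lower from compound 3 to compound 4 (beyond the scatter), so leaving that group for a much smaller one with no ring has a readable cost. The same group cannot be told apart from either of the other two, with a number 6 percentage points higher from compound 2 to compound 4 (within the scatter) and a number 8 percentage points lower from compound 1 to compound 4 (within the scatter), so cyano adds a second ring-free group to butyl, yet only the comparisons with compound 3 are beyond the scatter, and compound 1, with its ring, goes against any clean division by ring. Nothing measured explains these differences, and no independent data on the compounds bear on them.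

What the compounds shown leave open is whether a plain phenyl, a carboxylic acid or a longer chain on the same nitrogen would reach beyond the numbers seen so far. They also leave open how strong or weak the effect of any of these compounds would be at other concentrations, since each is described only by its effect at the one concentration tested in this assay.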